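Methylating the indazole nitrogen of a pyrazole urea

The compounds below may be only part of what the source reports. "The series", "measured", "known", "first", "only" and "open" are said of these compounds alone.

Compound 1 `CC(C)(C)c1cc(CNC(=O)Nc2cccc3[nH]ncc23)n(-c2ccc(F)cc2)n1` is the reference point. In an assay on CHO-K1 cells for antagonist activity at transient receptor potential cation channel subfamily V member 1 (Homo sapiens), read by FLIPR and calcium flux, with a stated time of 6 min (on this read-out higher numbers stand for weaker inhibition and lower numbers for stronger inhibition), compound 1 gives 2.2 nM, the lowest of the three numbers measured. Its two neighbours alter the aryl ring on the pyrazole nitrogen: compound 2 `COc1ccc(-n2nc(C(C)(C)C)cc2CNC(=O)Nc2cccc3[nH]ncc23)cc1` gives 62.9 nM, and compound 3 `CC(C)(C)c1ccc(-n2nc(C(C)(C)C)cc2CNC(=O)Nc2cccc3[nH]ncc23)cc1` gives 40 nM. Both steps are large, a 29-fold higher number from compound 1 to compound 2 (1.46 log units; beyond the scatter) and an 18-fold higher number from compound 1 to compound 3 (1.26 log units; beyond the scatter), while between themselves the two a 1.6-fold lower number from compound 2 to compound 3 (0.20 log units; within the scatter).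

Compound 4 `Cn1ncc2c(NC(=O)NCc3cc(C(C)(C)C)nn3-c3ccc(F)cc3)cccc21` leaves that aryl ring untouched and instead changes the other end of the molecule: methyl in place of hydrogen on an aromatic nitrogen. Within the data shown here, none of the measured steps touches this site, so they bear on the new change only as a reminder that single substitutions on this core have moved the number by large steps. Among the measured compounds shown here, with no direct precedent, a weakening step beyond the scatter is expected but far from certain, a 4.5-fold higher number from compound 1 to compound 4 (0.66 log units; beyond the scatter). Compound 4 is therefore estimated at 10 nM, with a range from 2 nM to 60 nM.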

Compound 4, inhibition constant: 4.5 nM
For compound 4 the middle estimate is 2.2-fold (0.35 log units) above the measured one; the measured number falls inside the stated range.
By their numbers in this assay, from the lowest: compound 1; then compound 4; then compounds 3 and 2 (each within the scatter of the next).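

In this assay the hydrogen on the aromatic nitrogen can give way to methyl at a modest cost, a 2.0-fold higher number from compound 1 to compound 4 (0.31 log units; beyond the scatter), which is beyond the scatter but much smaller than either change on the aryl ring, a 29-fold higher number from compound 1 to compound 2 (1.46 log units; beyond the scatter) and an 18-fold higher number from compound 1 to compound 3 (1.26 log units; beyond the scatter). This hydrogen is therefore not needed to keep the number low, and of the three changes to compound 1 shown, this one moves it least. Nothing available explains why the methyl costs so little.

The compounds shown leave open how a longer chain such as ethyl, or a chain ending in an amine or a carboxylic acid, would fare on this nitrogen. They also leave open whether the methyl step would be of similar size on compound 2 and compound 3.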